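Aromatic Amide Returns; Cytotoxicity Expected to Strengthen

The source may report more compounds than this note shows. Statements on the series, on what has been measured and on what is new or still open speak of the compounds shown alone.

Compound 1 `O=C(NCCCN1CCN(CCCNc2ccnc3cc(Cl)ccc23)CC1)c1ccc(Oc2ccccc2)cc1`: 1400 nM
Compound 2 `O=C(NCCCN1CCN(CCCNc2ccnc3cc(Cl)ccc23)CC1)c1ccccc1C(=O)c1ccccc1`: 3200 nM
Compound 3 `CC(C)=CC(=O)NCCCN1CCN(CCCNc2ccnc3cc(Cl)ccc23)CC1`: 30000 nM

In an ADME assay on L6 cells (Rattus norvegicus) for cytotoxicity (a lower number here means a stronger inhibitor, a higher number a weaker inhibitor), compound 1 gives 1400 nM and compound 2 gives 3200 nM, while compound 3 gives 30000 nM, the highest of the three numbers and beyond the scatter from both others. Compound 3 is the only one of the three with no aromatic ring attached to the carbonyl carbon. Compound 4 `O=C(NCCCN1CCN(CCCNc2ccnc3cc(Cl)ccc23)CC1)c1ccc(Cl)c([N+](=O)[O-])c1` differs from compound 3 in one place: 4-chloro-3-nitrophenyl in place of 2-methylprop-1-en-1-yl on a carbonyl carbon. An aromatic ring thus returns on the carbonyl carbon. A clear step toward a lower number is expected, a 10-fold lower number from compound 3 to compound 4 (1.00 log units; beyond the scatter), because compound 1 gives 1400 nM and because compound 2 gives 3200 nM. Compound 4 is estimated at 3000 nM, with a range from 1000 nM to 12000 nM.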

Compound 4, half-maximal inhibitory concentration: 11300 nM
Compound 4: the middle estimate sits 3.8-fold (0.58 log units) below what was measured, within the range that was stated.
By their numbers in this assay, from the lowest: compound 1; then compound 2; then compound 4; then compound 3.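

Going by these compounds alone, this is the first single change at this position on the carbonyl carbon: in this assay, 4-chloro-3-nitrophenyl in place of 2-methylprop-1-en-1-yl gives a 2.7-fold lower number from compound 3 to compound 4 (0.42 log units; beyond the scatter) and is labelled modest. An aromatic ring here therefore moves the number beyond the scatter, but only by a small margin. Nothing measured here explains this step.

As far as these compounds go, it remains open whether the ring itself or its chlorine and nitro groups account for the step. A plain phenyl group, or an amine in place of the nitro group, would help separate these contributions.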